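The compounds below may be only part of what the source reports. "The series", "measured", "known", "first", "only" and "open" are said of these compounds alone.

Values in a functional assay on PC-3 cells (Homo sapiens) for antiproliferative activity, read by sulforhodamine B assay, with a stated time of 48 h; a higher number here means a weaker inhibitor, a lower number a stronger inhibitor:

- Compound 1 `O=C(CCCCCCN1C(=O)/C(=N\O)c2ccccc21)NO`: 980 nM
- Compound 2 `O=C(CCCCCCN1C(=O)/C(=N\O)c2cc(F)ccc21)NO`: 2730 nM
- Compound 3 `CO/N=C1/C(=O)N(CCCCCCC(=O)NO)c2ccccc21`: 1670 nM

Compound 3, at 1670 nM, lies within the scatter of both compound 1 and compound 2, so its value cannot be separated from either of them.

The next compound is compound 4 `CO/N=C1/C(=O)N(CCCCCCC(=O)NO)c2ccc(Cl)cc21`, made from compound 3 by one change: chloro in place of hydrogen on an aromatic carbon. In words, this is chloro in place of hydrogen on an aromatic carbon.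

Within the data shown here, only one measured step bears on this change, a halogen replacing hydrogen on an aromatic carbon: a 2.8-fold higher number from compound 1 to compound 2 (0.44 log units; beyond the scatter). That step is modest but beyond the scatter, and it goes towards weaker inhibition. It is a weak guide, as it was measured with fluoro rather than chloro and starts from compound 1 rather than compound 3. Among the measured compounds shown here, no measured compound carries a chloro. A step in the same direction is therefore expected in this assay, somewhat smaller than the fluoro step and possibly not clear of the scatter.

The estimated change is a 1.7-fold higher number from compound 3 to compound 4 (0.22 log units; within the scatter).

Compound 4 is expected at about 2800 nM, with an estimated range of 1100 nM to 7000 nM.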

Compound 4, half-maximal inhibitory concentration: 2330 nM
Beside the measured number, compound 4's estimate is 1.2-fold (0.08 log units) above it; the measured number falls inside the stated range.
By their numbers in this assay, from the lowest: compounds 1, 3, 4 and 2 (each within the scatter of the next, the first and the last beyond it).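

In this assay, among these compounds, the first reading of chloro on this aromatic carbon, meta to a fused ring and para to a fused ring, is a 1.4-fold higher number from compound 3 to compound 4 (0.14 log units; within the scatter), so compound 3 and compound 4 cannot be told apart and the chloro is compatible with the antiproliferative activity seen for the series. Among the compounds shown here, the only other halogen step, a 2.8-fold higher number from compound 1 to compound 2 (0.44 log units; beyond the scatter), lies beyond the scatter, so a clear loss on adding a halogen to an aromatic carbon is seen for fluoro in that pair but does not appear for chloro in this one. Nothing measured here explains the two readings, and no supporting data bear on why the chloro step stays within the scatter.

With different halogens and different parent compounds in the two steps, the compounds shown do not separate the effect of the halogen from that of the group on the core's oxime oxygen. As far as these compounds go, it also remains open how a bromo, methoxy, trifluoromethyl or amine group on this aromatic carbon would read in this assay, and whether a longer chain to the hydroxamic acid would alter the picture.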